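This account rests on a few compounds, and the source may have more. Where it says the series, first, only, none or still open, it means among the compounds named here.

Compound 1 `Oc1ccc(-c2cc(-c3ccsc3)cc(-c3cccc(O)c3)n2)cc1` and compound 2 `Oc1ccc(-c2cc(-c3ccsc3)cc(-c3ccc(O)cc3)n2)cc1` share a core, and in a functional assay on DU-145 cells (Homo sapiens) for cytotoxicity, read by CCK-8 assay (a lower number here means a stronger inhibitor, a higher number a weaker inhibitor), compound 1 gives 2230 nM while compound 2 gives 2060 nM. Between them stands one change, (4-hydroxyphenyl in place of 3-hydroxyphenyl on an aromatic carbon), and the step it made, a 1.1-fold lower number from compound 1 to compound 2 (0.03 log units; within the scatter), is small. Compound 3 `Oc1cccc(-c2cc(-c3ccccn3)cc(-c3ccccc3O)n2)c1` is built on a different core; how the two cores differ is not broken down here. In this assay compound 3 gives 17100 nM, which stands clearly apart from compound 1 and compound 2.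

Compound 4 `Oc1ccc(-c2cc(-c3ccccn3)cc(-c3ccccc3O)n2)cc1` has not yet been measured. It differs from compound 3 by 4-hydroxyphenyl in place of 3-hydroxyphenyl on an aromatic carbon. This is the same kind of change as that from compound 1 to compound 2, though not the same: in compound 3 the place is meta to a 2-hydroxyphenyl group and meta to a pyridin-2-yl group, whereas in compound 1 it is meta to a 4-hydroxyphenyl group and meta to a thiophen-3-yl group. Among the measured compounds shown here, the only measured instance of this change gave a step within the scatter, so for compound 4 the expected step in this assay is a 1.1-fold lower number from compound 3 to compound 4 (0.06 log units; within the scatter), resting on compound 3 at 17100 nM and on the earlier step of a 1.1-fold lower number from compound 1 to compound 2 (0.03 log units; within the scatter). The estimate for compound 4 is therefore 15000 nM, between 6500 nM and 35000 nM.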

Compound 4, half-maximal inhibitory concentration: 25400 nM
Beside the measured number, compound 4's estimate is 1.7-fold (0.23 log units) below it; the measured number falls inside the stated range.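

In this assay, the new step is a 1.5-fold higher number from compound 3 to compound 4 (0.17 log units; within the scatter), so on the core of compound 3 the exchange of 3-hydroxyphenyl for 4-hydroxyphenyl stays within the scatter, as it did on the core of compound 1. Set side by side, the two steps do not differ: the same change on two cores in this assay, a 1.1-fold lower number (0.03 log units; within the scatter) from compound 1 to compound 2 and a 1.5-fold higher number (0.17 log units; within the scatter) from compound 3 to compound 4, 1.6-fold (0.21 log units) apart, within the scatter of two such steps. This shows that the exchange carried across these two cores without a step beyond the scatter, but two pairs do not show that it would do so on any other core, and they say nothing about the gap between the cores themselves.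

The compounds shown carry only hydroxyphenyl groups at this place, so it remains open how a methoxyphenyl, an aminophenyl or a carboxyphenyl group would read there. Also open is how much of the difference between the cores goes with thiophen-3-yl as against pyridin-2-yl, as no pair shown changes that group alone.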